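A few compounds are considered here, and "the series" means these few. Any claim that something is new, unique, unknown or untested is made for them only; others in the source may bear on it.

Working notes on the diaminopyrimidine-benzyl series in an assay for inhibition of Dihydrofolate reductase (Gallus gallus); on this read-out lower numbers stand for stronger inhibition and higher numbers for weaker inhibition.

Three members have been measured. Compound 1 `CCCCOc1ccccc1Cc1cnc(N)nc1N` gives 8710 nM. Compound 2 `Nc1ncc(Cc2ccccc2Br)c(N)n1` gives 12300 nM. Compound 3 `CS(=O)(=O)Oc1ccccc1Cc1cnc(N)nc1N` gives 22900 nM, the highest of the three numbers; its gap to compound 2 is within the scatter, while the step of a 2.6-fold higher number from compound 1 to compound 3 (0.42 log units; beyond the scatter) is modest but beyond it. The step of a 1.9-fold higher number from compound 2 to compound 3 (0.27 log units; within the scatter) stays within the scatter.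

Compound 4 `CCCCCCOc1ccccc1Cc1cnc(N)nc1N` is not yet measured. It differs from compound 3 by hexyl in place of methylsulfonyl on an oxygen on an aromatic ring. Among the compounds with values here, the only measured step that touches this position is a 2.6-fold higher number from compound 1 to compound 3 (0.42 log units; beyond the scatter), which runs the opposite way, from an alkyl chain on the oxygen to methylsulfonyl. Reversing that direction, and lengthening the chain from butyl to hexyl, a modest decrease in the number is expected; no measured pair tells how butyl and hexyl compare, so the range is kept wide.

Compound 4 is therefore expected to give 7000 nM, within 2500 nM to 20000 nM, an expected step of a 3.3-fold lower number from compound 3 to compound 4 (0.51 log units; beyond the scatter).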

Compound 4, inhibition constant: 7940 nM
Compound 4: the middle estimate sits 1.1-fold (0.05 log units) below what was measured; the range from low to high includes it.
By their numbers in this assay, from the lowest: compounds 4, 1, 2 and 3 (each within the scatter of the next, the first and the last beyond it).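

In this assay, within the data shown here, ethyl in place of hydrogen on the saturated chain gives a 1.1-fold lower number from compound 1 to compound 4 (0.04 log units; within the scatter), so the first direct comparison of chain lengths on this oxygen shows no difference between butyl and hexyl. Hexyl in place of methylsulfonyl gives a 2.9-fold lower number from compound 3 to compound 4 (0.46 log units; beyond the scatter), a modest step beyond the scatter that matches in direction the one already printed for butyl, so compound 1 and compound 4 both stand apart from compound 3. Hexyloxy in place of bromo gives a 1.5-fold lower number from compound 2 to compound 4 (0.19 log units; within the scatter), which leaves compound 2 and compound 4 unseparated.

No evidence is available that accounts for these numbers. From the compounds shown here alone, whether a longer chain such as octyl on this oxygen, or an amine in place of the hexyl, would shift the number beyond the scatter stays open.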